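The source may hold more compounds than are shown below. What is called first, only, known or untested is meant among the compounds shown, and "the series" means these compounds.

Among the compounds with values here, in an ADME assay on HepG2 cells (Homo sapiens) for cytotoxicity, read by MTT assay, with a stated time of 72 h (on this read-out lower numbers stand for higher toxicity in this test and higher numbers for lower toxicity in this test), compound 2 `CC(O)C#Cc1cc(Cl)cn2c([N+](=O)[O-])c(CS(=O)(=O)c3ccccc3)nc12` gives 44200 nM, the only true number so far. Compound 1 `O=[N+]([O-])c1c(CS(=O)(=O)c2ccccc2)nc2c(C#Cc3ccccc3)cc(Cl)cn12` gives > 3900 nM, which is a limit and not a number.

Next is compound 3 `O=[N+]([O-])c1c(CS(=O)(=O)c2ccccc2)nc2c(C#CC3(O)CCCCC3)cc(Cl)cn12`, which carries 1-hydroxycyclohexyl in place of 1-hydroxyethyl on a triple-bonded carbon.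

Within the data shown here, the only measured step bearing on this change is a step that the limit leaves unreadable from compound 1 to compound 2. It gives neither a size nor a firm direction, so the expectation rests on compound 2 at 44200 nM and stays loose. A moderate shift toward lower numbers in this assay is expected, though no change beyond the scatter remains possible. The expected step is a 2.2-fold lower number from compound 2 to compound 3 (0.34 log units; beyond the scatter). Compound 3 is estimated at 20000 nM, with an expected range of 6000 nM to 60000 nM.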

Compound 3, half-maximal cytotoxic concentration: > 25000 nM
Compound 3 ended at the assay's limit (the forecaster's own chance of this, stated with the estimate: 30%); middle value at least 1.2-fold (0.09 log units) from the limit.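

In this assay compound 3 gives > 25000 nM, which is a limit and not a number. Within the data shown here, no step from compound 1 or compound 2 to compound 3 can be read. On these data alone, whether 1-hydroxycyclohexyl in place of 1-hydroxyethyl or phenyl on a triple-bonded carbon shifts the half-maximal cytotoxic concentration, and in which direction, stays open.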